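Aryl variation on the shared core: compounds 1 to 4

A few compounds are considered here, and "the series" means these few. Any claim that something is new, unique, unknown or untested is made for them only; others in the source may bear on it.

Measured in a functional assay on PANC-1 cells (Homo sapiens) for inhibition, read by MTT assay, with a stated time of 24 h; a higher number here means a weaker inhibitor, a lower number a stronger inhibitor:
compound 1, `CC1(C)[C@H]2CC[C@]1(C)N(Cc1cn(-c3ccc(Cl)cc3)nn1)C(=O)C2`: 440 nM
compound 2, `Cc1ccc(-n2cc(CN3C(=O)C[C@@H]4CC[C@@]3(C)C4(C)C)nn2)cc1`: 270 nM
compound 3, `CC1(C)[C@H]2CC[C@]1(C)N(Cc1cn(-c3ccc(C#N)cc3)nn1)C(=O)C2`: 250 nM

Compound 3 sits at the low end of these three numbers, yet the step of a 1.1-fold lower number from compound 2 to compound 3 (0.03 log units; within the scatter) and the step of a 1.8-fold lower number from compound 1 to compound 3 (0.25 log units; within the scatter) both fall within the scatter, so the three compounds are not separated by this assay. Within the data shown here, the only change among them is the group on the aromatic carbon of the phenyl ring; the step of a 1.6-fold lower number from compound 1 to compound 2 (0.21 log units; within the scatter) is likewise within the scatter.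

Compound 4, `COc1cccc(-n2cc(CN3C(=O)C[C@@H]4CC[C@@]3(C)C4(C)C)nn2)c1`, has not yet been measured in this assay. Its change from compound 3 is 3-methoxyphenyl in place of 4-cyanophenyl on an aromatic nitrogen. All three measured steps bear on it, as each also exchanges the group on that phenyl ring, and none of them left the scatter. The change to compound 4 moves the group to a different ring position and exchanges nitrogen for oxygen, which the measured steps do not cover, so the expectation rests on the flat behaviour seen so far.

Compound 4 is therefore expected to give about 320 nM in this assay, within 130 nM to 800 nM, a step of a 1.3-fold higher number from compound 3 to compound 4 (0.11 log units; within the scatter) that is expected to stay within the scatter.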

Compound 4, half-maximal inhibitory concentration: 860 nM
For compound 4 the middle estimate is 2.7-fold (0.43 log units) below the measured one; measured number outside the range, above it.
By their numbers in this assay, from the lowest: compounds 3, 2, 1 and 4 (each within the scatter of the next, the first and the last beyond it).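

In this assay, the group on the aromatic nitrogen of the five-membered ring is no longer shown as flat: 3-methoxyphenyl in place of 4-cyanophenyl gives a 3.4-fold higher number from compound 3 to compound 4 (0.54 log units; beyond the scatter), and 3-methoxyphenyl in place of 4-methylphenyl gives a 3.2-fold higher number from compound 2 to compound 4 (0.50 log units; beyond the scatter), the first steps in this set to pass beyond the scatter, both modest. The pattern does not cover compound 1, which goes against it: 3-methoxyphenyl in place of 4-chlorophenyl gives a 2.0-fold higher number from compound 1 to compound 4 (0.29 log units; within the scatter), so the exchange does not separate those two compounds and its outcome depends on the group that leaves. No measurement at hand accounts for these steps.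

The compounds shown leave open whether the steps follow the methoxy group itself or its place on the phenyl ring, as compound 4 changes both at once, and 4-methoxyphenyl and 3-cyanophenyl groups would pull those two apart. Also open, from the compounds shown here alone, is how this assay reads a phenyl ring bearing an amine or a carboxylic acid at this nitrogen.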